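Cytotoxicity of a fluorinated amide analogue: an expected limit

The compounds below may be only part of what the source reports. "The series", "measured", "known", "first", "only" and "open" are said of these compounds alone.

Of the compounds shown here, three sharing one core have been tested in an ADME assay on Karpas-1106P cells (Homo sapiens) for cytotoxicity; a higher number here means that more compound is needed for the effect, a lower number that less compound is needed. Compound 1 `Cc1ccc(S(=O)(=O)N[C@@H](CC(=O)NC(C)(C)C)C(=O)NCCNS(=O)(=O)c2ccccc2)cc1` carries a phenylsulfonyl group on its terminal amine nitrogen; in this assay compound 1 gives only a limit, > 11100 nM. Compound 2 `Cc1ccc(S(=O)(=O)N[C@@H](CC(=O)NC(C)(C)C)C(=O)NCCNC(=O)c2c(O)cccc2F)cc1` carries a 2-fluoro-6-hydroxyphenyl carbonyl group instead; compound 2 likewise gives only a limit, > 11100 nM. Compound 3 `Cc1ccc(S(=O)(=O)N[C@@H](CC(=O)NC(C)(C)C)C(=O)NCCNC(=O)c2cccc(O)c2)cc1` has a 3-hydroxyphenyl carbonyl group; compound 3 too gives only a limit, > 11100 nM. All three sit at the limit of > 11100 nM in this assay, at which 3 of the 3 values shown sit, so the steps a step that the two limits leave unreadable from compound 1 to compound 2, a step that the two limits leave unreadable from compound 1 to compound 3 and a step that the two limits leave unreadable from compound 2 to compound 3 cannot be read. Compound 2 therefore stands at the limit, not at a number.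

Compound 4 `Cc1ccc(S(=O)(=O)N[C@@H](CC(=O)NC(C)(C)C)C(=O)NCCNC(=O)c2cccc(F)c2)cc1` is not yet measured. Relative to compound 2 the change is 3-fluorophenyl in place of 2-fluoro-6-hydroxyphenyl on a carbonyl carbon. Within the data shown here, the only measured step that touches the same carbonyl carbon, from compound 2 to compound 3, is unreadable, and no step here gives a direction or a size beyond the scatter. The step that the limit leaves unreadable from compound 2 to compound 4 is thus expected to stay unreadable. Compound 4 is expected to give about 20000 nM, within 8000 nM to 60000 nM, most likely again as a limit.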

Compound 4, half-maximal effective concentration: > 11100 nM
Compound 4 gave a limit, no number; the forecaster's own chance of this, stated with the estimate: 85%; the middle value does not contradict the limit.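

Compound 4 also gives only a limit, so its steps from compound 1, compound 2 and compound 3 cannot be read, and all four compounds stand at the same limit: the limit of > 11100 nM in this assay, at which 4 of the 4 values shown sit.

In this assay the compounds shown leave open whether any change on the shared core would give an actual number rather than a limit.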